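Swapping the ring-nitrogen acyl group for an arylsulfonyl

The compounds below may be only part of what the source reports. "The series", "measured", "known", "first", "only" and "open" are said of these compounds alone.

Measured compounds:
Compound 1 `CN(C)c1ccc(C2CC(c3ccc(-n4ccnc4)cc3)=NN2)cc1`: -20.9%
Compound 2 `COC(=O)CC(=O)N1N=C(c2ccc(N3CCN(C)CC3)cc2)CC1c1ccc(N(C)C)cc1`: -8.3%
Compound 3 `CN1CCN(c2ccc(C3=NN(C(=O)c4ccc(F)cc4)C(c4ccc(N(C)C)cc4)C3)cc2)CC1`: 31.8%

In a functional assay on HCC1806 cells (Homo sapiens) for inhibition, read by sulforhodamine B assay, tested at 10 uM (a lower number here means less inhibition, a higher number more inhibition at the concentration tested (going by the name of the read-out)), compound 3 gives the highest of the three numbers. Compound 2 is the nearest to it, and the step of a number 40.1 percentage points higher from compound 2 to compound 3 (beyond the scatter) separates them, a large one that comes with a 4-fluorophenyl in place of (methoxycarbonyl)methyl on a carbonyl carbon. Compound 1, which shares the 4-(dimethylamino)phenyl group but otherwise has a different substitution pattern, gives -20.9% in this assay, far below what compound 3 shows.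

Compound 4 `CN1CCN(c2ccc(C3=NN(S(=O)(=O)c4ccc(Br)cc4)C(c4ccc(N(C)C)cc4)C3)cc2)CC1` has not yet been measured. Its change from compound 3 is (4-bromophenyl)sulfonyl in place of (4-fluorophenyl)carbonyl on an amine nitrogen in a ring. Among the measured compounds shown here, the only measured step at this ring nitrogen, a number 40.1 percentage points higher from compound 2 to compound 3 (beyond the scatter), shows that what sits on the ring nitrogen can move the number a great deal; there the aryl group entered, and compound 4 keeps an aryl group, so that step does not tell whether a sulfonyl in place of a carbonyl on the same nitrogen shifts the number. For the measured compounds named here, no measured pair separates a carbonyl from a sulfonyl here.

With the aryl group retained, compound 4 is expected to stay near compound 3, the step of a number 6.8 percentage points lower from compound 3 to compound 4 (within the scatter) being the estimate. Compound 4 is thus estimated at 25% in this assay, with a range from -5% to 55%.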

Compound 4, a percentage reported as inhibition, at one concentration (the size of the read-out at that concentration, not a potency): 87.1%
Compound 4: middle estimate off by 62.1 percentage points, on the low side, and the stated range ends below it.
By their numbers in this assay, from the lowest: compound 1; then compound 2; then compound 3; then compound 4.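

In this assay the step of a number 55.3 percentage points higher from compound 3 to compound 4 (beyond the scatter) shows that an aryl group on this ring nitrogen does not by itself fix the number, since both compounds carry one and still lie far apart. What joins that ring to the nitrogen, or what the ring bears, therefore matters at this position as well, which the earlier comparison could not show because it changed a (methoxycarbonyl)methyl group into an aryl group. The widest gap so far at this one place, a number 95.4 percentage points higher from compound 2 to compound 4 (beyond the scatter) in the same assay, comes with the rest of the structure unchanged, and nothing available here accounts for the size of these steps.

The change from compound 3 to compound 4 alters the linking group and the halogen together, so the compounds shown leave open which of the two carries the step, a question that (4-fluorophenyl)sulfonyl or (4-bromophenyl)carbonyl on the same nitrogen would address. They also leave open whether the aryl ring is needed at all once a sulfonyl is present, as methylsulfonyl at this position would show.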